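The source may report more compounds than this note shows. Statements on the series, on what has been measured and on what is new or still open speak of the compounds shown alone.

Measured so far in a functional assay on MDA-MB-231 cells (Homo sapiens) for cytotoxicity, read by MTT assay, with a stated time of 72 h; on this read-out higher numbers stand for weaker inhibition and lower numbers for stronger inhibition:

Compound 1 `CC1(C)OCC(Cn2cc(Cn3c4c(c5ccccc53)C(=O)c3c[n+]([O-])c5ccccc5c3C4=O)nn2)O1`: 230 nM
Compound 2 `O=C1c2c[n+]([O-])c3ccccc3c2C(=O)c2c1c1ccccc1n2CCN1CCCC1`: 630 nM
Compound 3 `CC1(C)OC[C@H](Cn2cc(Cn3c4c(c5ccccc53)C(=O)c3c[n+]([O-])c5ccccc5c3C4=O)nn2)O1`: 530 nM

In this assay, compound 2 gives 630 nM. This is the highest of the three numbers, but it lies within the usual scatter of compound 3 at 530 nM. Only compound 1 at 230 nM stands apart from compound 2 by more than the scatter.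

The next compound to be measured is compound 4 `CN1CCN(CCCCCCn2c3c(c4ccccc42)C(=O)c2c[n+]([O-])c4ccccc4c2C3=O)CC1`, which differs from compound 2 at one place: 4-(4-methylpiperazin-1-yl)butyl in place of pyrrolidin-1-yl on a saturated chain carbon, two bonds along the chain from an aromatic nitrogen. It carries 4-(4-methylpiperazin-1-yl)butyl in place of pyrrolidin-1-yl on a saturated chain carbon, two bonds along the chain from an aromatic nitrogen.

Among the compounds with values here, the one measured step is a 2.3-fold higher number from compound 1 to compound 3 (0.36 log units; beyond the scatter), a modest one that comes with the fact that one of compounds 1 and 3 is drawn with a defined configuration and the other without, at the place where they differ. Within the data shown here, it bears only indirectly on this change, since no measured pair differs in chain or ring in this way. The expectation therefore rests on the spread of the measured values, from compound 1 at 230 nM to compound 2 at 630 nM. No step beyond the scatter is expected in this assay, and neither direction is favoured with any confidence. The expected change is a 1.4-fold lower number from compound 2 to compound 4 (0.15 log units; within the scatter). For compound 4 the estimated value is 450 nM, with an expected range from 130 nM to 1500 nM.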

Compound 4, half-maximal inhibitory concentration: 2400 nM
Compound 4: the middle estimate sits 5.3-fold (0.73 log units) below what was measured; the whole stated range lies below it.
By their numbers in this assay, from the lowest: compound 1; then compounds 3 and 2 (each within the scatter of the next); then compound 4.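

In this assay, putting 4-(4-methylpiperazin-1-yl)butyl in place of pyrrolidin-1-yl gives a 3.8-fold higher number from compound 2 to compound 4 (0.58 log units; beyond the scatter), so the place on a saturated chain carbon, two bonds along the chain from an aromatic nitrogen, does not tolerate every group equally. Within the data shown here, the only step measured earlier was one of drawn configuration; this is the first to show that exchanging the group itself can move the number beyond the scatter, here towards weaker inhibition, although ring and chain change together in this single step. Nothing measured here bears on why the number rises at this place.

On these data alone, it remains open whether the rise goes with the longer chain or with the exchange of the ring, a question that 4-methylpiperazin-1-yl on the chain of compound 2, or pyrrolidin-1-yl on a butyl chain, could separate. Also open, as far as these compounds go, is how other amines at this place, such as morpholin-4-yl or dimethylamino, would compare with pyrrolidin-1-yl in this assay.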